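The source may hold more compounds than are shown below. What is called first, only, known or untested is meant among the compounds shown, and "the series" means these compounds.

In a functional assay for inhibition, with Homo sapiens as the target (a higher number here means a weaker inhibitor, a lower number a stronger inhibitor), compound 1 (`CC1(c2ccc(C(=N)N)cc2)NC(=O)N(CC(=O)NC(CC(=O)O)c2cccnc2)C1=O`) gives 100 nM and compound 2 (`C[C@@]1(c2ccc(C(=N)N)cc2)NC(=O)N(CC(=O)N[C@@H](CC(=O)O)c2ccccc2)C1=O`) gives 20 nM, while compound 3 (`C[C@]1(c2ccc(C(=N)N)cc2)NC(=O)N(CC(=O)N[C@@H](CC(=O)O)c2ccccc2)C1=O`) has the highest number of the three at 6000 nM. The measured step that matters here is a 300-fold higher number from compound 2 to compound 3 (2.48 log units; beyond the scatter), and it comes from a single stereocentre at a saturated ring carbon. Compound 4 (`C[C@]1(c2ccc(C(=N)N)cc2)NC(=O)N(CC(=O)N[C@H](CC(=O)O)c2ccccc2)C1=O`) differs from compound 3 elsewhere: the two compounds have the same atoms and bonds; at least one stereo element is drawn with a configuration in one of them and without one in the other: 1 of 3 stereo elements differ; a stereocentre at a saturated chain carbon is drawn S in compound 3 and R in compound 4. Going by the values given here, the change is thus again a single stereocentre, but no measured step touches this chain carbon, so the ring-carbon step is only a loose guide. A moderate rise, well short of that step, is expected in this assay. The expected change is a 4.2-fold higher number from compound 3 to compound 4 (0.62 log units; beyond the scatter). For compound 4 the estimate is 25000 nM, within a range of 5000 nM to 100000 nM.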

Compound 4, half-maximal inhibitory concentration: 5000 nM
The estimate for compound 4 lay 5.0-fold (0.70 log units) above the measured number; measured number inside the range.
By their numbers in this assay, from the lowest: compound 2; then compound 1; then compounds 4 and 3 (each within the scatter of the next).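

In this assay, inverting the chain carbon while the ring carbon stays R gives a 1.2-fold lower number from compound 3 to compound 4 (0.08 log units; within the scatter), so with the ring carbon drawn R, this second stereocentre has no effect that can be read. Inverting both centres gives a 250-fold higher number from compound 2 to compound 4 (2.40 log units; beyond the scatter), and the large gap from compound 2 therefore stays in place whichever way the chain carbon is drawn, as long as the ring carbon is R.

Going by these compounds, it remains open whether the chain carbon matters when the ring carbon is drawn S. Also open is how an ester in place of the carboxylic acid would behave.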